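From 3-hydroxyazetidin-1-yl to 3-hydroxypyrrolidin-1-yl in compound 1

The compounds below may be only part of what the source reports. "The series", "measured", "known", "first", "only" and "open" are said of these compounds alone.

compound 1 `Nc1ncc(-c2ccc(C(=O)N3CC(O)C3)cc2)nc1-c1ccc(C(F)(F)F)cc1`: > 90%
compound 2 `Nc1ccc(-c2nc(-c3ccc(S(=O)(=O)C4CC4)cc3)cnc2N)cn1`: > 90%
compound 3 `N#Cc1ccc(-c2cnc(N)c(-c3ccc(N)nc3)n2)cc1`: > 90%

In an ADME assay on microsomes from liver (Mus musculus) for metabolic stability, read by LC-MS, using NADPH, with a stated time of 30 min, tested at 0.1 uM, in the presence of a further agent that is not named here (a lower number here means that less of the compound is left, a higher number that more of the compound is left), compound 1 gives > 90%, which is a limit of the assay and not a number. Compound 2 gives > 90%, also a limit. Compound 3 gives > 90%, again a limit. The three readings therefore have one thing in common: the limit of > 90% in this assay, at which 3 of the 3 values shown sit. Compound 1 shares this position with both other compounds, and no number separates them.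

Compound 4 `Nc1ncc(-c2ccc(C(=O)N3CC[C@H](O)C3)cc2)nc1-c1ccc(C(F)(F)F)cc1` keeps the rest of compound 1 and alters the group on the carbonyl carbon: 3-hydroxypyrrolidin-1-yl in place of 3-hydroxyazetidin-1-yl on a carbonyl carbon. The entering group also brings a defined stereocentre.

Among the measured compounds shown here, only one step has been measured, a step that the two limits leave unreadable from compound 2 to compound 3. It concerns cyano in place of cyclopropylsulfonyl on an aromatic carbon, and it gives no size to carry over. For the measured compounds named here, no measured step covers a change on the carbonyl carbon, so the expectation rests on the position of compound 1 alone. With compound 1 at > 90%, a limit, no clear move in either direction is expected. The expected step is a number at least 2 percentage points lower from compound 1 to compound 4 (that floor lies within the scatter). For compound 4 the estimated value is 88%, with an expected range from 70% to 100%.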

Compound 4, percent of the compound remaining: > 90%
Compound 4: no number, only a limit; the forecaster's own chance of this, stated with the estimate: 55%; middle value at least 2 percentage points from the limit.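

In this assay compound 4 gives > 90%, which is a limit of the assay and not a number. Among the compounds shown here, no step from compound 1 to compound 4 can therefore be read. The compounds shown leave open whether 3-hydroxypyrrolidin-1-yl in place of 3-hydroxyazetidin-1-yl on a carbonyl carbon changes this reading at all, and all of them stand at one position: the limit of > 90% in this assay, at which 4 of the 4 values shown sit.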